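Swapping chloro for methoxy on a benzyl arm

The source may report more compounds than this note shows. Statements on the series, on what has been measured and on what is new or still open speak of the compounds shown alone.

compound 1, `CCOC(=O)c1cccc(-c2n[nH]c3ccccc23)c1`, 5650 nM
compound 2, `CCOC(=O)c1ccc(-c2nn(Cc3ccc(Cl)cc3)c3ccccc23)cc1`, 120 nM

Of the compounds shown here, two have been measured in a functional assay on cells (Platelet, Homo sapiens) for inhibition; a lower number here means a stronger inhibitor, a higher number a weaker inhibitor. Compound 1 gives 5650 nM, while compound 2 gives 120 nM, the lower of the two numbers, and the gap between the two values is beyond the usual scatter. Compound 3, `CCOC(=O)c1ccc(-c2nn(Cc3ccc(OC)cc3)c3ccccc23)cc1`, has not yet been measured. It differs from compound 2 in one place: methoxy in place of chloro on an aromatic carbon. Going by the values given here, no pair of measured compounds differing in a single place is available, so there is no earlier example of this exchange to draw on. The expectation is a small move, perhaps toward a slightly higher number, but one that may not go beyond the scatter. For compound 3 the estimate is 200 nM, with an expected range from 60 nM to 700 nM. This corresponds to an expected step of a 1.7-fold higher number from compound 2 to compound 3 (0.22 log units; within the scatter).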

Compound 3, half-maximal inhibitory concentration: 620 nM
Compound 3: the middle estimate sits 3.1-fold (0.49 log units) below what was measured; measured number inside the range.
By their numbers in this assay, from the lowest: compound 2; then compound 3; then compound 1.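

Going by these compounds alone, this is the first single change that can be read directly: in this assay replacing 4-chlorobenzyl with 4-methoxybenzyl gives a 5.2-fold higher number from compound 2 to compound 3 (0.71 log units; beyond the scatter) and so moves the number beyond the usual scatter. The number therefore responds to what sits on this aromatic carbon, para to a large group, and of these two groups chloro gives the stronger inhibitor. Nothing shown here explains why the step occurs.

Within the data shown here, with only two groups compared at this place, it remains open whether fluoro, methyl or an amine would give a lower or higher number than chloro or methoxy. As far as these compounds go, it is also open whether the same exchange would give a similar step if the ethyl ester on the other side of the molecule were a carboxylic acid.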